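From a limit toward a number: lengthening the sulfur chain

The compounds below may be only part of what the source reports. "The series", "measured", "known", "first", "only" and "open" are said of these compounds alone.

Compound 3 `COc1cc(-c2nnc(SC)n2-c2ccc(N(C)C)cc2)cc(OC)c1OC` is one of three measured compounds sharing the same core, and in a functional assay on HT-29 cells (Homo sapiens) for inhibition, read by MTT assay, with a stated time of 48 h (a lower number here means a stronger inhibitor, a higher number a weaker inhibitor), compound 3 reaches only the limit > 60000 nM, not a number. Compound 1 `COc1ccc(-n2c(S)nnc2-c2cc(OC)c(OC)c(OC)c2)cc1` likewise gives only the limit > 60000 nM in this assay. Compound 2 `COc1ccc(-n2c(SCC(=O)c3ccc(F)cc3)nnc2-c2cc(OC)c(OC)c(OC)c2)cc1` gives 42500 nM in this assay, and the step of an at least 1.4-fold lower number from compound 1 to compound 2 (0.14 log units; that floor lies within the scatter) shows what replacing the hydrogen on the sulfur did there. Compound 4 `COc1cc(-c2nnc(SCC(=O)Nc3ccc(Cl)cc3)n2-c2ccc(N(C)C)cc2)cc(OC)c1OC` differs from compound 3 by (4-chlorophenyl)carbamoyl in place of hydrogen on a saturated chain carbon bound to a sulfur That change resembles the one behind an at least 1.4-fold lower number from compound 1 to compound 2 (0.14 log units; that floor lies within the scatter), which is measured against the limit of > 60000 nM in this assay, at which 2 of the 3 values shown sit, and so only sets a floor. The step of an at least 1.5-fold lower number from compound 3 to compound 4 (0.17 log units; that floor lies within the scatter) is therefore expected to be small, perhaps none beyond the scatter. Compound 4 is estimated at 40000 nM, between 10000 nM and 100000 nM.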

Compound 4, half-maximal inhibitory concentration: > 60000 nM
Compound 4 gave a limit, no number; the forecaster's own chance of this, stated with the estimate: 50%; at least 1.5-fold (0.17 log units) between middle value and limit.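

In this assay, going by these compounds alone, compound 4 gives only a limit of > 60000 nM and not a number, so no step from compound 3 to compound 4 can be read. The compounds shown leave open whether (4-chlorophenyl)carbamoyl in place of hydrogen changes inhibition at all.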